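This account rests on a few compounds, and the source may have more. Where it says the series, first, only, none or still open, it means among the compounds named here.

Measured so far:
compound 1 `CC(C)N(Cc1cccc(OCCCCCC(=O)O)c1)C(=O)c1ccccc1` — in an ADME assay on HEK293 cells (Homo sapiens) for cytotoxicity, read by CellTiter-Glo and resazurin assay, with a stated time of 72 h (a lower number here means that less compound is needed, a higher number that more compound is needed for the effect), compound 1 gives > 26000 nM, a limit of the assay.
compound 2 `CC(C)N(Cc1cccc(OCCCCCC(=O)O)c1)C(=O)c1ccc(-c2cccc3ccccc23)cc1` — in this assay compound 2 gives > 26000 nM, also a limit.
compound 3 `CC(=O)Nc1cccc(-c2ccc(C(=O)N(Cc3cccc(OCCCCCC(=O)O)c3)C(C)C)cc2)c1` — in this assay compound 3 gives > 26000 nM, again a limit.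

Compound 3 thus stands at the ceiling of this assay, together with the other two compounds (the limit of > 26000 nM in this assay, at which 3 of the 3 values shown sit). The steps a step that the two limits leave unreadable from compound 1 to compound 2, a step that the two limits leave unreadable from compound 1 to compound 3 and a step that the two limits leave unreadable from compound 2 to compound 3 are all unreadable, both ends being limits. Compound 4 `CC(C)N(Cc1cccc(OCCCCCC(=O)O)c1)C(=O)c1ccc(-c2ccncc2)cc1` carries pyridin-4-yl in place of 3-acetamidophenyl on an aromatic carbon. No readable step bears on this change, so no direction can be taken from the series. Compound 4 is expected to remain at the limit, with a step that the limit leaves unreadable from compound 3 to compound 4 expected to lie within scatter. The estimate for compound 4 is 30000 nM, range 15000 nM to 60000 nM.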

Compound 4, half-maximal effective concentration: > 26000 nM
Compound 4 ended at the assay's limit; the forecaster's own chance of this, stated with the estimate: 85%; the middle value is on the limit's open side.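

No new step can be read: compound 1, compound 2, compound 3 and compound 4 all sit at one limit, so every step among them stays unreadable: the limit of > 26000 nM in this assay, at which 4 of the 4 values shown sit.

From the compounds shown here alone, the concentration giving a half-maximal effect in this assay stays open for all four compounds, and with it any ranking of naphthalen-1-yl, 3-acetamidophenyl and pyridin-4-yl.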